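Coumarin-pyrazoline sulfanylacetamides: nitro to bromo on the arylthio

The compounds below may be only part of what the source reports. "The series", "measured", "known", "first", "only" and "open" are said of these compounds alone.

Measured compounds:
- compound 1, `O=C(CSc1ccc([N+](=O)[O-])cc1)N1N=C(c2cc3ccccc3oc2=O)C[C@@H]1c1ccc(C(F)(F)F)cc1`, 10200 nM
- compound 2, `CCCCSCC(=O)N1N=C(c2cc3ccccc3oc2=O)C[C@@H]1c1ccc(C(F)(F)F)cc1`, 2350 nM
- compound 3, `O=C(CSc1ccc([N+](=O)[O-])cc1)N1N=C(c2cc3ccccc3oc2=O)C[C@@H]1c1ccccc1C(F)(F)F`, 7580 nM

In a functional assay on MGC-803 cells (Homo sapiens) for cytotoxicity, read by MTT assay, with a stated time of 48 h (on this read-out lower numbers stand for stronger inhibition and higher numbers for weaker inhibition), compound 3 stands second highest of the three numbers. Its nearest neighbour is compound 1, and the two lie within the scatter: a 1.3-fold lower number from compound 1 to compound 3 (0.13 log units; within the scatter). Among the measured compounds shown here, the only step beyond the scatter in this set is a 4.3-fold lower number from compound 1 to compound 2 (0.64 log units; beyond the scatter), which replaces the whole group on the sulfur; compound 2 gives 2350 nM.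

Compound 4, `O=C(CSc1ccc(Br)cc1)N1N=C(c2cc3ccccc3oc2=O)C[C@@H]1c1ccccc1C(F)(F)F`, is not yet measured. It differs from compound 3 in one place: bromo in place of nitro on an aromatic carbon. For the measured compounds named here, no measured pair changes the substituent on this aromatic ring while leaving the rest of the molecule intact. The step of a 4.3-fold lower number from compound 1 to compound 2 (0.64 log units; beyond the scatter) is the only one that touches the sulfur side at all, and it exchanges the entire 4-nitrophenyl for butyl, a larger alteration than the present one. The step of a 1.3-fold lower number from compound 1 to compound 3 (0.13 log units; within the scatter) concerns the other aryl group and does not bear on this change.

Going by the values given here, with no direct precedent, a step of at most modest size is expected in this assay, direction uncertain, and the range must stay wide. Compound 4 is expected to give 6000 nM, between 2500 nM and 15000 nM, which means an expected step of a 1.3-fold lower number from compound 3 to compound 4 (0.10 log units; within the scatter).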

Compound 4, half-maximal inhibitory concentration: 21300 nM
Compound 4: middle estimate off by 3.6-fold (0.55 log units), on the low side; measured number outside the range, above it.
By their numbers in this assay, from the lowest: compound 2; then compounds 3 and 1 (each within the scatter of the next); then compound 4.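

In this assay, bromo in place of nitro on the arylthio ring gives a 2.8-fold higher number from compound 3 to compound 4 (0.45 log units; beyond the scatter), so the substituent at this ring position, para to a large group, can alone move the number beyond the scatter, with the rest of the molecule intact. Of the two groups at this position, nitro goes with the lower number and therefore the stronger inhibition, although this rests on one pair carrying 2-(trifluoromethyl)phenyl; the sulfur side also responded in a 4.3-fold lower number from compound 1 to compound 2 (0.64 log units; beyond the scatter), whereas the move of the trifluoromethyl group on the other aryl gave only a 1.3-fold lower number from compound 1 to compound 3 (0.13 log units; within the scatter), within the scatter. Nothing in the data given accounts for the direction of the step.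

As far as these compounds go, it remains open whether bromo in place of nitro has the same direction and size with 4-(trifluoromethyl)phenyl on the saturated ring carbon, since one pair cannot separate a general effect from one tied to this aryl group. From the compounds shown here alone, it is also open how an amine, a carboxylic acid or a methoxy group would read at this ring position, and whether a chain longer than butyl on the sulfur would keep the lower number of compound 2.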